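A few compounds are considered here, and "the series" means these few. Any claim that something is new, unique, unknown or untested is made for them only; others in the source may bear on it.

Measured compounds: compound 1 `COc1cc(Oc2cccc(Nc3ccccc3)c2)cc(OC)c1CNCc1ccccc1` gives 5220 nM in a functional assay on DLD-1 cells (Homo sapiens) for inhibition, read by MTT assay, with a stated time of 72 h; on this read-out lower numbers stand for stronger inhibition and higher numbers for weaker inhibition; compound 2 `COc1cc(Oc2cccc(Nc3ccccc3)c2)cc(OC)c1CN[C@H](C)c1ccccc1` gives 8570 nM.

Compound 2 has the higher of the two numbers, but the step of a 1.6-fold higher number from compound 1 to compound 2 (0.22 log units; within the scatter) leaves it within the scatter of compound 1. Compound 3 `COc1cc(Oc2cccc(Nc3ccccc3)c2)cc(OC)c1CNCc1ccc(Br)cc1` differs from compound 2 by 4-bromobenzyl in place of 1-phenylethyl on an amine nitrogen. Among the measured compounds shown here, only the single step from compound 1 to compound 2 bears on this, and it is small; the bromine carries no measured step at all. Compound 3 is therefore expected to show no step beyond the scatter, a 1.6-fold lower number from compound 2 to compound 3 (0.19 log units; within the scatter), with an estimated value of 5500 nM, between 2000 nM and 15000 nM.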

Compound 3, half-maximal inhibitory concentration: 3520 nM
Beside the measured number, compound 3's estimate is 1.6-fold (0.19 log units) above it; the range from low to high includes it.
By their numbers in this assay, from the lowest: compounds 3, 1 and 2 (each within the scatter of the next, the first and the last beyond it).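

In this assay, among the compounds shown here, 4-bromobenzyl in place of 1-phenylethyl on an amine nitrogen gives a 2.4-fold lower number from compound 2 to compound 3 (0.39 log units; beyond the scatter), the first step to pass the scatter. Bromo in place of hydrogen on an aromatic carbon alone gives a 1.5-fold lower number from compound 1 to compound 3 (0.17 log units; within the scatter), so the bromine by itself cannot be told apart from the plain benzyl, and the larger step appears only between the two ends of the series. Nothing at hand explains these numbers.

On these data alone, whether a 4-chlorobenzyl or 4-methoxybenzyl group on the same nitrogen would read alike remains open.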